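Trading a Methoxyphenyl for a Fluorophenyl Group

This account rests on a few compounds, and the source may have more. Where it says the series, first, only, none or still open, it means among the compounds named here.

Compound 1 `COc1ccc(N2CCN(C(=S)SCc3ccc(C(=O)Nc4ccccc4N)cc3)CC2)cc1` was tested in a functional assay on MGC-803 cells (Homo sapiens) for antiproliferative activity, read by CCK-8 assay, with a stated time of 72 h, tested at 8 uM (a higher number here means a stronger effect of the compound at the concentration tested, a lower number a weaker effect), where compound 1 gives 22.9%. This is the lower of the two numbers seen so far, yet compound 2 `Nc1ccccc1NC(=O)c1ccc(CSC(=S)N(Cc2ccccc2)Cc2ccccc2)cc1` gives 30.7% in this assay, and the two values lie within the scatter of the measurement. Compound 3 `Nc1ccccc1NC(=O)c1ccc(CSC(=S)N2CCN(c3ccccc3F)CC2)cc1` has not been measured. It differs from compound 1 in one place: 2-fluorophenyl in place of 4-methoxyphenyl on an amine nitrogen in a ring. Within the data shown here, no measured pair shows what such a swap does, so no shift beyond the scatter is expected. The step of a number 2.1 percentage points higher from compound 1 to compound 3 (within the scatter) is expected to be small. Compound 3 is therefore estimated at 25%, within a range from 12% to 40%.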

Compound 3, a percentage reported as inhibition, at one concentration (the size of the read-out at that concentration, not a potency): 86.4%
Estimate against measurement, compound 3: 61.4 percentage points below, outside the stated range (above it).
By their numbers in this assay, from the lowest: compounds 1 and 2 (each within the scatter of the next); then compound 3.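

The swap from 4-methoxyphenyl to 2-fluorophenyl on the amine nitrogen in the ring gives a number 63.5 percentage points higher from compound 1 to compound 3 (beyond the scatter) in this assay, so the group at this position can have a large effect on the read-out. Compound 1 and compound 2 differ in more than one place, so they could not show this. Nothing shown here explains the rise.

From the compounds shown here alone, the swap changes both the substituent and where it sits on the phenyl ring, so it remains open which change matters. Comparing 2-methoxyphenyl, 4-fluorophenyl or plain phenyl on the same nitrogen would separate the two.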